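Replacing a Dimethoxyphenyl Thioether Group with Ethylphenyl

The source may report more compounds than this note shows. Statements on the series, on what has been measured and on what is new or still open speak of the compounds shown alone.

Compound 1 `COc1ccc(SCc2ccc(/C=C/C(=O)Nc3ccccc3N)cc2)cc1OC`: 21.9%
Compound 2 `Nc1ccccc1NC(=O)c1ccc(CSc2ccc(Br)cc2)cc1`: 38.2%
Compound 3 `COC(=O)c1ccccc1SCc1ccc(C(=O)Nc2ccccc2N)cc1`: 55.5%

All three were tested in a functional assay on HeLa cells (Homo sapiens) for inhibition, read by CCK-8 assay, with a stated time of 72 h, tested at 8 uM; a higher number here means more inhibition of growth at the concentration tested, a lower number less inhibition of growth. Compound 1 stands lowest of the three numbers; compound 2 lies higher by a margin beyond the scatter, and compound 3 higher still. Compound 4 `CCc1ccc(SCc2ccc(/C=C/C(=O)Nc3ccccc3N)cc2)cc1` has not yet been measured. It differs from compound 1 in one place: 4-ethylphenyl in place of 3,4-dimethoxyphenyl on a sulfur. For the measured compounds named here, no two measured compounds differ in a single place, so no measured step weighs such an exchange, and compounds 2 and 3 differ from compound 1 at several places at once. In this assay a small step is expected, upward if any, likely not beyond the scatter. Compound 4 is estimated at 28%, within 12% to 48%, an expected step of a number 6.1 percentage points higher from compound 1 to compound 4 (within the scatter).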

Compound 4, percent growth inhibition at one concentration: 20.9%
Compound 4: the middle estimate sits 7.1 percentage points above what was measured; measured number inside the range.
By their numbers in this assay, from the lowest: compounds 4 and 1 (each within the scatter of the next); then compound 2; then compound 3.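

In this assay, for the compounds shown here, the exchange of 3,4-dimethoxyphenyl for 4-ethylphenyl on a sulfur gives a number 1 percentage points lower from compound 1 to compound 4 (within the scatter) as the first step in this set that changes one place alone. At this position, the two oxygens of the leaving group can therefore give way to an all-carbon ethyl group with no change beyond the scatter. Nothing at hand explains this result. On these data alone, it remains open whether an amine or a carboxylic acid on this phenyl ring would shift the number beyond the scatter. As far as these compounds go, a longer chain in place of the ethyl also remains untested here.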